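Methylsulfonyl tail on the propoxy chain of compound 2

A few compounds are considered here, and "the series" means these few. Any claim that something is new, unique, unknown or untested is made for them only; others in the source may bear on it.

compound 1: `COc1cc(C)c(-c2cccc(COc3ccc4c(c3)S(=O)(=O)CC4CC(=O)O)c2)c(C)c1` — > 1000 nM
compound 2: `CCCOc1cc(C)c(-c2cccc(COc3ccc(S(=O)(=O)CC(=O)O)cc3)c2)c(C)c1` — 69.2 nM

Within the data shown here, in a functional assay on CHO cells for agonist activity at Free fatty acid receptor 1 (Homo sapiens), read by FLIPR and calcium flux (on this read-out higher numbers stand for an effect only at larger amounts of compound and lower numbers for an effect already at smaller amounts), compound 2 gives 69.2 nM, the only number obtained so far. For compound 1 the entry > 1000 nM is a limit of the assay and not a number, namely (the limit of > 1000 nM in this assay, at which 1 of the 2 values shown sits). Compound 3 `Cc1cc(OCCCS(C)(=O)=O)cc(C)c1-c1cccc(COc2ccc(S(=O)(=O)CC(=O)O)cc2)c1` differs from compound 2 by methylsulfonyl in place of hydrogen on a saturated chain carbon, three bonds along the chain from an oxygen on an aromatic ring. Among the measured compounds shown here, no measured pair shows this change, so its direction is open. The step is expected to stay within the usual scatter, a 1.3-fold higher number from compound 2 to compound 3 (0.11 log units; within the scatter). Compound 3 is therefore expected to give about 90 nM, between 30 nM and 350 nM.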

Compound 3, half-maximal effective concentration: 170 nM
Beside the measured number, compound 3's estimate is 1.9-fold (0.28 log units) below it, and the stated range covers the measured number.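

Among these compounds, the end of the propyl chain is the first place where a one-place change can be read, and in this assay methylsulfonyl in place of hydrogen there gives a 2.5-fold higher number from compound 2 to compound 3 (0.39 log units; beyond the scatter) in a modest step. The chain therefore carries this group with a measurable but limited cost, and compound 3 still gives a number, 170 nM, and not a limit. Nothing measured here explains this step. On these data alone, whether a hydroxyl or an amine on the same chain carbon, or a longer chain ending in methylsulfonyl, would give a lower or a higher number remains open.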